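A few compounds are considered here, and "the series" means these few. Any claim that something is new, unique, unknown or untested is made for them only; others in the source may bear on it.

Series notes. Among the measured compounds shown here, compound 2 `COc1cc(C)c(/C=C/C(C)=C/C=C(F)/C(C)=C/C(=O)O)c(C)c1C` stands highest of the three measured members in a functional assay on the whole organism (strain Hart Swiss) with Mus musculus as the target, with stated times of 5 days and 2 weeks, at a dose of 10 mg/kg by the intraperitoneal route; a higher number here means a stronger effect of the compound at the dose given, a lower number a weaker effect: compound 2 gives 80%. Compound 3 `COc1cc(C)c(/C=C/C(C)=C(F)/C=C/C(C)=C/C(=O)O)c(C)c1C` comes nearest; in this assay compound 3 gives 54%, a gap beyond the scatter. Compound 1 `CCOC(=O)/C(F)=C(C)/C=C/C=C(C)/C=C/c1c(C)cc(OC)c(C)c1C` stands furthest; in this assay compound 1 gives 37%, also beyond the scatter. For the measured compounds named here, no single-point step between measured compounds is available, so neither gap can be tied to one structural change.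

Compound 4 `CCOC(=O)/C=C(C)/C(F)=C/C=C(C)/C=C/c1c(C)cc(OC)c(C)c1C` has not been measured. It differs from compound 2 in one place: ethyl in place of hydrogen on an oxygen next to a carbonyl group. Compound 1 carries the same ethoxycarbonyl group, yet it also differs from compound 2 elsewhere, so its value cannot serve as a direct reading of this change. A decrease beyond the scatter is expected, though with wide uncertainty, because compound 1 gives 37% as the only ester measured. The step from compound 2 to compound 4 is therefore expected to be a number 20 percentage points lower from compound 2 to compound 4 (beyond the scatter). Compound 4 is estimated at 60%, within a range from 35% to 85%, pending the actual reading in this assay.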

Compound 4, a percentage reported as activity, at one dose (the size of the read-out at that dose, not a potency): 76%
Compound 4: middle estimate off by 16 percentage points, on the low side; the range from low to high includes it.
By their numbers in this assay, from the lowest: compound 1; then compound 3; then compounds 4 and 2 (each within the scatter of the next).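

In this assay, ethyl in place of hydrogen on an oxygen next to a carbonyl group reads as a number 4 percentage points lower from compound 2 to compound 4 (within the scatter) and gives the series its first single-point step. For this pair, then, the free carboxy group is not needed for a high reading at this dose, since with the ethoxycarbonyl group compound 4 gives 76% and stays within the scatter of compound 2, and the reading of compound 1 proves no guide to this change. No measured property bears on this step, so the data offer no account of how the two compounds come to read alike.

On these data alone, whether this holds for other groups on the same oxygen stays open, for example methyl, a longer chain, or an amide in place of the ester. As far as these compounds go, the step also comes from a single pair, so it remains open whether ethyl in place of hydrogen at the same oxygen of compound 3, whose fluorine sits elsewhere, would read the same way.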